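This account rests on a few compounds, and the source may have more. Where it says the series, first, only, none or still open, it means among the compounds named here.

Measured to date:
- compound 2, `N=C(N)NCCC[C@H](NC(=O)CN(c1nc(Cl)nc2[nH]cnc12)C1CC1)C(=O)O`: 51%
- compound 1, `O=C(CN(c1nc(Cl)nc2[nH]cnc12)C1CC1)N[C@@H](CO)C(=O)OCc1ccccc1`: 34.2%
- compound 3, `N=C(N)NCCC[C@H](NC(=O)CN(c1nc(Cl)nc2[nH]cnc12)C1CC1)C(=O)OCc1ccccc1`: 30.6%

In a functional assay on the whole organism (Tail, strain ICR) with Mus musculus as the target, in the tail flick test, with a stated time of 60 min, at a dose of 25 umol/kg by the oral route (on this read-out higher numbers stand for a stronger effect at the one dose given and lower numbers for a weaker effect), compound 2 gives 51%, the highest of the three numbers; the nearest is compound 1 with 34.2% and the furthest compound 3 with 30.6%, both gaps beyond the scatter.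

Compound 4, `NC(=O)C[C@H](NC(=O)CN(c1nc(Cl)nc2[nH]cnc12)C1CC1)C(=O)O`, is not yet measured. It differs from compound 2 by a group of 3 heavy atoms (1 carbon, 1 nitrogen, 1 oxygen; no ring) in place of a group of 6 heavy atoms (3 carbon, 3 nitrogen; no ring), on a saturated chain carbon, two bonds along the chain from an amide-type nitrogen and a carbonyl carbon.

Of the measured steps, only the change from compound 1 to compound 3 sits at the same place, swapping the group at that chain carbon on the benzyl ester: a number 3.6 percentage points lower from compound 1 to compound 3 (within the scatter), within the scatter. The step from compound 2 to compound 3 changes a different place, the oxygen beside the carbonyl, and does not bear on this swap: a number 20.4 percentage points lower from compound 2 to compound 3 (beyond the scatter). One within-scatter step at the relevant place gives a thin basis; the expectation for this assay is a step of no more than the scatter, if anything slightly downward, a number 5 percentage points lower from compound 2 to compound 4 (within the scatter). Compound 4 is therefore estimated at 46%, in the range 30% to 62%.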

Compound 4, a percentage reported as activity, at one dose (the size of the read-out at that dose, not a potency): 43.1%
Compound 4: middle estimate off by 2.9 percentage points, on the high side; low and high end bracket the measured number.
By their numbers in this assay, from the lowest: compounds 3, 1, 4 and 2 (each within the scatter of the next, the first and the last beyond it).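

In this assay, replacing the group of 6 heavy atoms with carbamoyl on the saturated chain carbon gives a number 7.9 percentage points lower from compound 2 to compound 4 (within the scatter), so this position now has a swap read without the benzyl ester. With a number 3.6 percentage points lower from compound 1 to compound 3 (within the scatter) on the benzyl ester side, both swaps at this chain carbon stay within the scatter, and none of the four compounds goes against this, though the pattern rests on only these two pairs. Nothing available explains the size of either step.

Still open, as far as these compounds go, is whether benzyl on the oxygen next to a carbonyl group would lower the number on the carbamoyl compound as it does in a number 20.4 percentage points lower from compound 2 to compound 3 (beyond the scatter). From the compounds shown here alone, it is also open how a simple amine, a carboxylic acid or a longer chain at this chain carbon would read at this one dose.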